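Phenyl in place of methoxypyridinyl on the pyrazole carboxylic acid

The source may hold more compounds than are shown below. What is called first, only, known or untested is meant among the compounds shown, and "the series" means these compounds.

Working notes on a series sharing the core shown in compound 1 `COc1cc(-c2c(C)nn(-c3nc(-c4ccc(Cl)c(Cl)c4)c(SC(C)C)s3)c2C(=O)O)cc(C(F)(F)F)c1`. In a functional assay on BJAB cells (Homo sapiens) for antiproliferative activity, with a stated time of 4 days (on this read-out higher numbers stand for an effect only at larger amounts of compound and lower numbers for an effect already at smaller amounts), compound 1 gives 1380 nM. Compound 2 `COc1cncc(-c2c(C)nn(-c3nc(-c4ccc(Cl)c(Cl)c4)c(SC(C)C)s3)c2C(=O)O)c1` carries a 5-methoxypyridin-3-yl group in place of the 3-methoxy-5-(trifluoromethyl)phenyl group of compound 1. In this assay compound 2 gives 21000 nM. Its number is the highest of the three measured, and the step of a 15-fold higher number from compound 1 to compound 2 (1.18 log units; beyond the scatter) is well beyond the scatter. Compound 3 `Cc1nn(-c2nc(-c3ccc(Cl)c(Cl)c3)c(SC(C)C)s2)c(C(=O)O)c1-c1cccc(Cl)c1` gives 13600 nM in this assay; the step of a 1.5-fold lower number from compound 2 to compound 3 (0.19 log units; within the scatter) lies within the scatter, so compounds 2 and 3 show no separation here.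

Compound 4 `Cc1nn(-c2nc(-c3ccc(Cl)c(Cl)c3)c(SC(C)C)s2)c(C(=O)O)c1-c1ccccc1` is not yet measured. Its change from compound 2 is phenyl in place of 5-methoxypyridin-3-yl on an aromatic carbon. Among the measured compounds shown here, the step of a 1.5-fold lower number from compound 2 to compound 3 (0.19 log units; within the scatter), a related exchange of the same group for a chlorophenyl group, is the closest precedent and shows no movement beyond the scatter. The step of a 15-fold higher number from compound 1 to compound 2 (1.18 log units; beyond the scatter) shows that this position does move the read-out, but nothing measured here separates an unsubstituted phenyl from the chlorophenyl of compound 3. The expected step of a 1.1-fold lower number from compound 2 to compound 4 (0.02 log units; within the scatter) is therefore small, not beyond the scatter. Compound 4 is estimated at 20000 nM in this assay, with a range of 7000 nM to 60000 nM.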

Compound 4, half-maximal effective concentration: 3000 nM
For compound 4 the middle estimate is 6.7-fold (0.82 log units) above the measured one; measured number outside the range, below it.
By their numbers in this assay, from the lowest: compound 1; then compound 4; then compounds 3 and 2 (each within the scatter of the next).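

In this assay, the unsubstituted phenyl separates from both earlier groups, with a 7.0-fold lower number from compound 2 to compound 4 (0.85 log units; beyond the scatter) and a 4.5-fold lower number from compound 3 to compound 4 (0.66 log units; beyond the scatter), although the 5-methoxypyridin-3-yl and 3-chlorophenyl groups showed no separation from each other. Substitution on this phenyl does not act in one direction: the chloro of compound 3 goes with a higher number, whereas the 3-methoxy-5-(trifluoromethyl)phenyl group goes against that trend, as seen in a 2.2-fold higher number from compound 1 to compound 4 (0.34 log units; beyond the scatter). Nothing available explains these shifts.

Going by these compounds, it remains open whether the lower number of compound 1 comes from the methoxy, the trifluoromethyl or the two together. Also open, on these data alone, is how a phenyl bearing an amine or a nitrile at this position would read in this assay.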